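Shortening a side chain and what it may do to solubility

The source may report more compounds than this note shows. Statements on the series, on what has been measured and on what is new or still open speak of the compounds shown alone.

Of the compounds shown here, two with a shared core have been measured in a physicochemical assay for solubility, read by spectrophotometry, in phosphate buffer, with a stated time of 2 h, at pH 7.4; on this read-out higher numbers stand for higher solubility and lower numbers for lower solubility. Compound 1 `COc1cccc(CN2C(=O)CN(C(=O)c3cc4cc(OC)ccc4[nH]3)C[C@@H]2COCc2ccccc2)c1` carries a benzyloxy group on a chain next to the ring, and in this assay compound 1 gives 11700 nM. Compound 2 `COc1cccc(CN2C(=O)CN(C(=O)c3cc4cc(OC)ccc4[nH]3)C[C@@H]2CCc2ccccc2)c1` carries a phenethyl group at the same ring position instead, and in this assay compound 2 gives 5100 nM. Among the compounds with values here, compound 2 thus stands lowest of the two numbers, and the only step seen so far, a 2.3-fold lower number from compound 1 to compound 2 (0.36 log units; beyond the scatter), is a modest drop.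

Compound 3 `COc1cccc(CN2C(=O)CN(C(=O)c3cc4cc(OC)ccc4[nH]3)C[C@@H]2c2ccccc2)c1` is the next step from compound 2: phenyl in place of phenethyl on a saturated ring carbon. This is a change of a different kind from the one already measured, since it shortens the side group rather than swapping an oxygen for a carbon, so the earlier step offers only a loose guide. With nothing directly comparable to rest on, the expected outcome is a small step from compound 2 to compound 3, if any, estimated as a 1.3-fold higher number from compound 2 to compound 3 (0.11 log units; within the scatter). Compound 3 is therefore expected to give about 6500 nM in this assay, within a range from 2800 nM to 15000 nM.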

Compound 3, solubility: 13600 nM
The estimate for compound 3 lay 2.1-fold (0.32 log units) below the measured number, and the stated range covers the measured number.
By their numbers in this assay, from the lowest: compound 2; then compounds 1 and 3 (each within the scatter of the next).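

Replacing phenethyl with phenyl on a saturated ring carbon removes chain while keeping the phenyl ring, and the number still moves in this assay, with a 2.7-fold higher number from compound 2 to compound 3 (0.43 log units; beyond the scatter); the earlier pair showed a change only within the chain, not a change in its length. Phenyl in place of (benzyloxy)methyl gives a 1.2-fold higher number from compound 1 to compound 3 (0.07 log units; within the scatter), so these two very different groups cannot be told apart at this position. Chain length alone therefore does not order the three compounds: compound 2 stands apart from the other two, beyond the scatter from each, while compound 1, with its (benzyloxy)methyl group, goes against any rule that a shorter group simply gives a higher number.

Nothing available explains why the numbers fall as they do. Still open, as far as these compounds go, is where a benzyl group, whose length lies between phenyl and phenethyl, would fall in this assay, and what an amine or a carboxylic acid at the end of the chain on this ring carbon would give.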